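Working notes: from compound 3 to compound 4

A few compounds are considered here, and "the series" means these few. Any claim that something is new, unique, unknown or untested is made for them only; others in the source may bear on it.

compound 1 `O=[N+]([O-])c1ccc(NC(=S)Nc2cccc(C(F)(F)F)c2)cc1` gives 10000 nM
compound 2 `N#Cc1ccc(NC(=S)Nc2cccc(C(F)(F)F)c2)cc1` gives 10000 nM
compound 3 `FC(F)(F)c1cccc(NC(=S)Nc2ccccc2)c1` gives 49000 nM

In an ADME assay on MDBK cells (Bos taurus) for cytotoxicity, read by MTT assay, with a stated time of 96 h (on this read-out lower numbers stand for higher toxicity in this test and higher numbers for lower toxicity in this test), compound 3 holds the highest number of the three at 49000 nM, beyond the scatter of both others. Compound 4 `Fc1ccccc1NC(=S)Nc1cccc(C(F)(F)F)c1` has fluoro in place of hydrogen on an aromatic carbon, ortho to a large group (fluoro in place of hydrogen on an aromatic carbon). Hydrogen in place of nitro shows a 4.9-fold higher number from compound 1 to compound 3 (0.69 log units; beyond the scatter) and hydrogen in place of cyano shows a 4.9-fold higher number from compound 2 to compound 3 (0.69 log units; beyond the scatter), both modest, while cyano in place of nitro shows no change at the digits printed from compound 1 to compound 2 (within the scatter). These steps involve other groups and guide only loosely. A small drop in this assay is therefore expected, no larger than those modest steps. The expected step is a 1.6-fold lower number from compound 3 to compound 4 (0.21 log units; within the scatter) for this change. Compound 4 is estimated at 30000 nM, with an expected range of 13000 nM to 60000 nM.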

Compound 4, half-maximal cytotoxic concentration: > 100000 nM
Compound 4: only a limit was reported; the forecaster's own chance of this, stated with the estimate: 10%; at least 3.3-fold (0.52 log units) between middle value and limit.
By their numbers in this assay, from the lowest: compounds 1 and 2 (each within the scatter of the next); then compound 3. At a limit, above all of these: compound 4.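

In this assay compound 4 gives > 100000 nM, which is a limit of the assay and not a number: the limit of > 100000 nM in this assay, at which 1 of the 4 values shown sits. Phenyl to 2-fluorophenyl gives an at least 2.0-fold higher number from compound 3 to compound 4 (0.30 log units; that floor lies within the scatter), so the true size of this step stays unknown. Nitro and cyano on this ring, in compound 1 and compound 2, go with lower numbers than hydrogen in compound 3, whereas fluoro, ortho to a large group, brings no lower number.

Open, as far as these compounds go, are the true value of compound 4 and whether this effect belongs to fluoro or to its place. An amine or a methoxy group at the same place could test this.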